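Replacing 4-fluorophenyl with 3,4-dihydroxyphenyl

The source may hold more compounds than are shown below. What is called first, only, known or untested is meant among the compounds shown, and "the series" means these compounds.

Compound 1 `O=C(CC(c1ccc(F)cc1)c1c[nH]c2ccccc12)c1c(O)c2ccccc2oc1=O`: 47.4 ug/mL
Compound 2 `COc1ccc(C(CC(=O)c2c(O)c3ccccc3oc2=O)c2c[nH]c3ccccc23)c(OC)c1`: 13.2 ug/mL
Compound 3 `COc1ccc(C(CC(=O)c2c(O)c3ccccc3oc2=O)c2c[nH]c3ccccc23)cc1OC`: 63.2 ug/mL

In a physicochemical assay, read by spectrophotometry, with a stated time of 30 min (a lower number here means a stronger inhibitor, a higher number a weaker inhibitor), compound 1 gives 47.4 ug/mL, at the high end of the numbers. The gap to its nearest neighbour is only a 1.3-fold higher number from compound 1 to compound 3 (0.12 log units; within the scatter), while the furthest lies at a 3.6-fold lower number from compound 1 to compound 2 (0.56 log units; beyond the scatter).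

The next candidate is compound 4 `O=C(CC(c1ccc(O)c(O)c1)c1c[nH]c2ccccc12)c1c(O)c2ccccc2oc1=O`. Its change is 3,4-dihydroxyphenyl in place of 4-fluorophenyl on a saturated chain carbon bound to an aromatic carbon and a saturated chain carbon. Both measured replacements of the 4-fluorophenyl group bear on this change, and the same two steps set the likely size. The 3,4-dihydroxyphenyl group of compound 4 resembles the 3,4-dimethoxyphenyl group of compound 3, which alone suggests little movement. However, the comparison of the two dimethoxyphenyl groups, a 4.8-fold higher number from compound 2 to compound 3 (0.68 log units; beyond the scatter), shows that this place can respond to the ring's substitution. Among the measured compounds shown here, no measured compound carries hydroxyl groups on this ring, so the evidence is indirect. A modest move towards a lower number is expected, though a result within the scatter would be no surprise. The expected step is a 2.4-fold lower number from compound 1 to compound 4 (0.37 log units; beyond the scatter). The estimate for compound 4 is 20 ug/mL, with an expected range of 6 ug/mL to 60 ug/mL.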

Compound 4, half-maximal inhibitory concentration: 71.1 ug/mL
Beside the measured number, compound 4's estimate is 3.6-fold (0.55 log units) below it, and the stated range ends below it.
By their numbers in this assay, from the lowest: compound 2; then compounds 1, 3 and 4 (each within the scatter of the next).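

In this assay, 3,4-dihydroxyphenyl in place of 4-fluorophenyl on this saturated chain carbon gives a step within the scatter (a 1.5-fold higher number from compound 1 to compound 4 (0.18 log units; within the scatter)), and so does 3,4-dihydroxyphenyl in place of 3,4-dimethoxyphenyl (a 1.1-fold higher number from compound 3 to compound 4 (0.05 log units; within the scatter)). Compounds 1, 3 and 4 therefore cannot be told apart here, even though 3,4-dihydroxyphenyl brings hydrogen-bond donors that the other two groups lack. Compound 2 still stands apart, with a step beyond the scatter (a 5.4-fold higher number from compound 2 to compound 4 (0.73 log units; beyond the scatter)), so among these four compounds only its 2,4-dimethoxyphenyl group shifts the number clearly.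

Nothing shown gives a reason for either result. Also open, on these data alone, is whether a ring carrying an amine or a carboxylic acid at this position would stay with compounds 1, 3 and 4 or move towards compound 2.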